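The compounds below may be only part of what the source reports. "The series", "measured", "known", "first", "only" and "open" are said of these compounds alone.

In an ADME assay on HaCaT cells (Homo sapiens) for cytotoxicity, read by MTT assay, with a stated time of 48 h (a lower number here means that less compound is needed, a higher number that more compound is needed for the effect), three compounds of this series have been measured. Compound 2 `CCCCOC(=O)[C@@H](N)CCC(=O)NCCSC(=O)c1ccccc1` gives 97000 nM, compound 1 `CCOC(=O)[C@@H](N)CCC(=O)NCCSC(=O)c1ccccc1` gives 331000 nM, and compound 3 `CCCCOC(=O)[C@@H](N)CCC(=O)NCCSC(C)=O` gives 563000 nM. Compound 1 differs from compound 2 by hydrogen in place of ethyl on a saturated chain carbon, two bonds along the chain from an oxygen next to a carbonyl group, and this step is a 3.4-fold higher number from compound 2 to compound 1 (0.53 log units; beyond the scatter). Compound 3 differs from compound 2 in its core by methyl in place of phenyl on a carbonyl carbon, which is a 5.8-fold higher number from compound 2 to compound 3 (0.76 log units; beyond the scatter). Compound 4 `CCOC(=O)[C@@H](N)CCC(=O)NCCSC(C)=O` has not yet been measured in this assay; it differs from compound 3 by hydrogen in place of ethyl on a saturated chain carbon, two bonds along the chain from an oxygen next to a carbonyl group, the same change that leads from compound 2 to compound 1, now on the other core. Since the change gave a 3.4-fold higher number from compound 2 to compound 1 (0.53 log units; beyond the scatter) in this assay, a step of similar size is expected here, namely a 2.7-fold higher number from compound 3 to compound 4 (0.43 log units; beyond the scatter). Compound 4 is therefore estimated at 1500000 nM, with a likely range from 700000 nM to 4000000 nM.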

Compound 4, half-maximal effective concentration in the HaCaT assay: 1730000 nM
For compound 4 the middle estimate is 1.2-fold (0.06 log units) below the measured one, within the range that was stated.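

In the HaCaT assay, hydrogen in place of ethyl gives a 3.1-fold higher number from compound 3 to compound 4 (0.49 log units; beyond the scatter), and this step matches the one on the other core: the same change on two cores in the HaCaT assay, a 3.4-fold higher number (0.53 log units; beyond the scatter) from compound 2 to compound 1 and a 3.1-fold higher number (0.49 log units; beyond the scatter) from compound 3 to compound 4, 1.1-fold (0.05 log units) apart, within the scatter of two such steps In the HaCaT assay, methyl in place of phenyl on a carbonyl carbon gives a 5.2-fold higher number from compound 1 to compound 4 (0.72 log units; beyond the scatter), and this step also keeps its size: the same change on two cores in the HaCaT assay, a 5.8-fold higher number (0.76 log units; beyond the scatter) from compound 2 to compound 3 and a 5.2-fold higher number (0.72 log units; beyond the scatter) from compound 1 to compound 4, 1.1-fold (0.05 log units) apart, within the scatter of two such steps Both changes therefore carried across the two cores shown, but four compounds cannot show that either change would carry to any other core, nor do they explain why the steps agree. In a physicochemical assay for acid dissociation, using potentiometric titration, at pH 2, compound 3 gives 8.69 and compound 4 gives 8.94, and hydrogen in place of ethyl here amounts to a number 0.25 log units higher from compound 3 to compound 4 (within the scatter).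

The compounds shown leave open whether the same steps would hold with a chain longer than butyl. They also leave open what a carboxylic acid in place of the ester would give.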